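Changing the Amide Substituent: From Compound 2 to Compound 3

This account rests on a few compounds, and the source may have more. Where it says the series, first, only, none or still open, it means among the compounds named here.

Compound 1, `Cc1cccc(Oc2ccnc(N3CCC[C@H]3C(=O)NCc3cccnc3)n2)c1`: 0%
Compound 2, `Cc1cccc(Oc2ccnc(N3CCC[C@H]3C(=O)NCCCn3ccnc3)n2)c1`: 0%

In an assay on isolated protein for inhibition of calcium/calmodulin-dependent protein kinase type II subunit alpha (Homo sapiens), read by HTRF, tested at 10 uM (a higher number here means more inhibition at the concentration tested (going by the name of the read-out), a lower number less inhibition), compound 1 gives 0% and compound 2 gives 0%. The step of no change at the digits printed from compound 1 to compound 2 (within the scatter) lies within the scatter, so compound 2 stands level with compound 1. Compound 3, `COC(=O)C(CO)NC(=O)[C@@H]1CCCN1c1nccc(Oc2cccc(C)c2)n1`, differs from compound 2 by 2-hydroxy-1-(methoxycarbonyl)ethyl in place of 3-(1H-imidazol-1-yl)propyl on an amide-type nitrogen. Within the data shown here, only that one measured step touches the group on the amide-type nitrogen, and it was flat. Compound 3 is therefore expected to show no step beyond the scatter in this assay, no change at the digits printed from compound 2 to compound 3 (within the scatter). The estimate for compound 3 is 0%, expected to fall between -8% and 12%.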

Compound 3, a percentage reported as inhibition, at one concentration (the size of the read-out at that concentration, not a potency): 0%
Compound 3: the middle estimate sits on the measured number at the digits printed; measured number inside the range.
By their numbers in this assay, from the lowest: compounds 1, 2 and 3 (each within the scatter of the next).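

In this assay, putting 2-hydroxy-1-(methoxycarbonyl)ethyl on the amide-type nitrogen gives no change at the digits printed from compound 2 to compound 3 (within the scatter) and also no change at the digits printed from compound 1 to compound 3 (within the scatter). The flat reading therefore no longer rests on groups that carry an aromatic ring, since this group has no ring and reads the same. Nothing available explains this flat result.

Still open, as far as these compounds go, is whether an amine or a carboxylic acid on this nitrogen would give any inhibition at all. The same holds for a change to the shared core.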